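Phenoxy for isopropoxy on the coumarin-type series, step to compound 4

The compounds below may be only part of what the source reports. "The series", "measured", "known", "first", "only" and "open" are said of these compounds alone.

Measured so far:
compound 1 `O=c1cc(O)c2ccc(OCc3cccc(F)c3)cc2o1` gives 0%
compound 2 `COc1cc(=O)oc2cc(OCc3cccc(Br)c3)ccc12` gives 27%
compound 3 `CC(C)Oc1cc(=O)oc2cc(OCc3cccc(Cl)c3)ccc12` gives 3%

All three numbers come from an assay on isolated protein (strain Sprague-Dawley) for inhibition of Amine oxidase [flavin-containing] A (Rattus norvegicus), read by spectrophotometry, with a stated time of 5 min, tested at 10 uM; on this read-out higher numbers stand for more inhibition at the one concentration tested (going by the name of the read-out) and lower numbers for less inhibition. Compound 3 stands second highest of the three, but its nearest neighbour is compound 1, whose number lies within the scatter of it, so the two cannot be told apart. For the measured compounds named here, compound 2 stands beyond the scatter above compound 3 and is the only number of the three that clearly rises off the floor.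

The next compound is compound 4 `O=c1cc(Oc2ccccc2)c2ccc(OCc3cccc(Cl)c3)cc2o1`. Its difference from compound 3 is phenyl in place of isopropyl on an oxygen on an aromatic ring. Going by the values given here, no step between two measured compounds matches this change, so its size has to be guessed. Among the compounds with values here, compound 2 shows that a small group on this oxygen can go with a number above the scatter, while compound 3 shows that the isopropyl group goes with a number near zero; the phenyl group on that oxygen has no precedent here.

The expectation is a step of a number 7 percentage points higher from compound 3 to compound 4 (within the scatter) in this assay, within the scatter or barely beyond it. Compound 4 is estimated at 10%, with a range from 0% to 35%.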

Compound 4, a percentage reported as inhibition, at one concentration (the size of the read-out at that concentration, not a potency): 0%
Compound 4: the middle estimate sits 10 percentage points above what was measured; the measured number falls inside the stated range.
By their numbers in this assay, from the lowest: compounds 1, 4 and 3 (each within the scatter of the next); then compound 2.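

In this assay, the change from isopropoxy to phenoxy gives a number 3 percentage points lower from compound 3 to compound 4 (within the scatter), the first step read at this oxygen with the rest of the molecule held the same, and the two groups cannot be told apart. An aromatic ring of carbon only, with 6 heavy atoms in place of 3, is thus taken at this place with no change beyond the scatter, and neither compound rises clearly off the floor of the read-out. No measurement on hand bears on why the two groups read alike.

From the compounds shown here alone, compound 2 differs from compound 3 in more than one place, so its higher number in this assay cannot yet be tied to the group on this oxygen, and a direct one-place comparison of methoxy with isopropoxy or phenoxy remains open. Also open, going by these compounds, is whether anything on this oxygen lifts the number with the rest of the molecule held fixed, for example a benzyl group, a longer alkyl chain, a chain ending in an amine, or a carboxylic acid.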